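Dropping a Methoxy Group: What Growth Inhibition to Expect

The source may hold more compounds than are shown below. What is called first, only, known or untested is meant among the compounds shown, and "the series" means these compounds.

compound 1 `COc1ccc(-c2[nH]c3ccccc3c2/C=C(\C#N)S(=O)(=O)c2ccccc2)cc1`: 2800 nM
compound 2 `COc1ccc(-c2[nH]c3ccc(OC)cc3c2/C=C(\C#N)S(=O)(=O)c2ccccc2)cc1`: 3700 nM
compound 3 `COc1ccc(-c2[nH]c3ccc(OC)cc3c2C=C(C#N)C#N)cc1`: 1500 nM

All three compounds were tested in a functional assay on NCI-H226 cells (Homo sapiens) for inhibition, read by sulforhodamine B assay, with a stated time of 48 h; a lower number here means a stronger inhibitor of growth, a higher number a weaker inhibitor of growth. Compound 1 gives the second highest of the three numbers. Its nearest neighbour is compound 2, and the step of a 1.3-fold higher number from compound 1 to compound 2 (0.12 log units; within the scatter) lies within the scatter of the measurement. Compound 3 gives a lower number than compound 1, but that gap is also within the scatter, so the three compounds cannot be ranked against one another on these data.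

Compound 4 `N#C/C(=C\c1c(-c2ccccc2)[nH]c2ccccc12)S(=O)(=O)c1ccccc1` differs from compound 1 in one place: hydrogen in place of methoxy on an aromatic carbon. Among the measured compounds shown here, the only measured step that involves a methoxy group is the one from compound 1 to compound 2, where a methoxy was added on the other aromatic ring of the shared core, and that step stayed within the scatter. For the measured compounds named here, no measured step touches the methoxy group that is removed here, so the expectation rests on a loose parallel only. On that basis the step from compound 1 to compound 4 is expected to stay within the scatter, as a 1.1-fold higher number from compound 1 to compound 4 (0.03 log units; within the scatter). Compound 4 is therefore estimated to give 3000 nM in this assay, with a range from 1200 nM to 7500 nM.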

Compound 4, concentration for 50% growth inhibition: 4100 nM
Compound 4: the middle estimate sits 1.4-fold (0.14 log units) below what was measured; the range from low to high includes it.
By their numbers in this assay, from the lowest: compounds 3, 1, 2 and 4 (each within the scatter of the next, the first and the last beyond it).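

Going from 4-methoxyphenyl to phenyl gives a 1.5-fold higher number from compound 1 to compound 4 (0.17 log units; within the scatter) in this assay, so this position now has a measured step of its own, and exchanging methoxy for hydrogen here produces no difference that can be told apart from the ordinary spread of repeated measurements. The earlier step, a 1.3-fold higher number from compound 1 to compound 2 (0.12 log units; within the scatter), concerned a methoxy at a different place on the shared core, so these two steps together show that, in this small set, a methoxy at either place makes no readable difference to the number. Nothing available explains this outcome, and a step within the scatter cannot rule out a small real effect.

On these data alone, at this position, only methoxy and hydrogen can be compared, so it remains open whether an amine, a carboxylic acid or a longer chain such as butoxy, placed on the same ring, would carry the number beyond the scatter. As far as these compounds go, it is also open whether the change from 4-methoxyphenyl to phenyl would read the same way in a compound carrying the two nitriles of compound 3.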